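Replacing 2-(trifluoromethyl)phenyl with 4-methoxyphenyl in compound 2

The compounds below may be only part of what the source reports. "The series", "measured", "known", "first", "only" and "open" are said of these compounds alone.

Compound 1 `COc1cc(OC)c(OC)cc1/C=C/COC(=O)/C=C/c1c(OC)ccc(OC)c1OC`: 476 umol/kg
Compound 2 `COc1cc(OC)c(OC)cc1/C=C/COC(=O)/C=C/c1ccccc1C(F)(F)F`: > 473 umol/kg (a limit)
Compound 3 `COc1cc(OC)c(OC)cc1/C=C/COC(=O)/C=C/c1cc(OC)c(OC)c(OC)c1`: 459 umol/kg

All three were tested in a functional assay on the whole organism (strain Kunming) with Mus musculus as the target, with a stated time of 0.5 h; a higher number here means that more compound is needed for the effect, a lower number that less compound is needed. Compound 2 stands at the limit of > 473 umol/kg in this assay, at which 1 of the 3 values shown sits; this is a limit, not a number.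

Compound 4 `COc1ccc(/C=C/C(=O)OC/C=C/c2cc(OC)c(OC)cc2OC)cc1` keeps the rest of compound 2 and changes one group: 4-methoxyphenyl in place of 2-(trifluoromethyl)phenyl on a double-bonded chain carbon bound to a double-bonded chain carbon. Going by the values given here, no measured pair here shows the effect of a single change. With compound 1 at 476 umol/kg and compound 3 at 459 umol/kg, two values within the usual scatter of each other, a step no larger than the scatter is expected in this assay. The estimated change is an at least 1.0-fold lower number from compound 2 to compound 4 (0.03 log units; that floor lies within the scatter). Compound 4 is estimated at 440 umol/kg, with an expected range of 240 umol/kg to 750 umol/kg.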

Compound 4, dose for half-maximal effect: 634 umol/kg
Beside the measured number, compound 4's estimate is 1.4-fold (0.16 log units) below it, and the stated range covers the measured number.
By their numbers in this assay, from the lowest: compounds 3, 1 and 4 (each within the scatter of the next).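

No step from compound 2 to compound 4 can be read, because compound 2 carries only a limit, not a number: the limit of > 473 umol/kg in this assay, at which 1 of the 4 values shown sits.

The compounds shown leave open how much 4-methoxyphenyl in place of 2-(trifluoromethyl)phenyl alone changes the dose needed in this assay.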